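The compounds below may be only part of what the source reports. "The series", "measured", "known", "first", "only" and "open" are said of these compounds alone.

Measured compounds:
compound 1, `CCc1cnc(N2CCC(n3ncc4cc(-c5ccc(S(C)(=O)=O)cc5)ccc43)CC2)nc1` — in a functional assay on HEK293 cells for agonist activity at Glucose-dependent insulinotropic receptor (Homo sapiens), read by HTRF and cAMP accumulation, with a stated time of 30 min (a higher number here means that more compound is needed for the effect, a lower number that less compound is needed), compound 1 gives 14 nM
compound 2, `CCc1cnc(N2CCC(n3ncc4cc(-c5ccc(S(C)(=O)=O)cc5)c(C)cc43)CC2)nc1` — in this assay compound 2 gives 70 nM
compound 3, `CCNC(=O)c1ccc(-c2cc3nnn(C4CCN(c5ncc(CC)cn5)CC4)c3cn2)c(C)c1` — in this assay compound 3 gives 19 nM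

For the measured compounds named here, the one single-point step in the set is methyl in place of hydrogen on an aromatic carbon which gives a 5.0-fold higher number from compound 1 to compound 2 (0.70 log units; beyond the scatter). The difference between the core of compound 1 and the core of compound 3 is not broken down here; their values lie within the scatter of each other.

Compound 4, `CCNC(=O)c1cc(C)c(-c2cc3nnn(C4CCN(c5ncc(CC)cn5)CC4)c3cn2)c(C)c1`, is not yet measured. It differs from compound 3 by methyl in place of hydrogen on an aromatic carbon. This is the same kind of change as from compound 1 to compound 2, but the surroundings differ: there the methyl sat ortho to a 4-(methylsulfonyl)phenyl group, meta to a fused ring and para to a fused ring; here it sits ortho to a large group, meta to a methyl group and meta to an ethylcarbamoyl group. On a different core, and with one methyl already present, the earlier step is only a rough guide.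

Because a 5.0-fold higher number from compound 1 to compound 2 (0.70 log units; beyond the scatter) was modest but beyond the scatter, a step of similar size is expected in this assay, namely a 3.7-fold higher number from compound 3 to compound 4 (0.57 log units; beyond the scatter). Compound 4 is accordingly estimated at 70 nM, with a likely range of 25 nM to 200 nM.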

Compound 4, half-maximal effective concentration in the Glucose-dependent insulinotropic receptor assay: 83 nM
Estimate against measurement, compound 4: 1.2-fold (0.07 log units) below; the range from low to high includes it.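

In the Glucose-dependent insulinotropic receptor assay compound 4 gives 83 nM and methyl in place of hydrogen on an aromatic carbon gives a 4.4-fold higher number from compound 3 to compound 4 (0.64 log units; beyond the scatter), and this step matches the earlier one on the other core: the same change on two cores in the Glucose-dependent insulinotropic receptor assay, a 5.0-fold higher number (0.70 log units; beyond the scatter) from compound 1 to compound 2 and a 4.4-fold higher number (0.64 log units; beyond the scatter) from compound 3 to compound 4, 1.1-fold (0.06 log units) apart, within the scatter of two such steps

In a physicochemical assay for solubility, read by HPLC, in phosphate buffer, measured as thermodynamic solubility, with a stated time of 24 h, at pH 6.8 (on this read-out higher numbers stand for higher solubility and lower numbers for lower solubility), compound 3 gives < 90 nM, which is a limit of the assay and not a number: the limit of < 90 nM in the physicochemical assay, at which 1 of the 2 values shown sits.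

In the physicochemical assay compound 4 gives 1860 nM and this is a measured number.

The same change in the physicochemical assay gives an at least 20-fold higher number from compound 3 to compound 4 (1.31 log units; beyond the scatter), but this is read on one core only, and two cores with the methyl in different surroundings give no rule for other cores.

Open, as far as these compounds go, is whether ethyl, methoxy or chlorine in place of this methyl would give a step of similar size in the Glucose-dependent insulinotropic receptor assay. Also open, from the compounds shown here alone, is how the methyl step behaves on the core of compound 1 in the physicochemical assay.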